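The compounds below may be only part of what the source reports. "The series", "measured", "known", "first", "only" and "open" are said of these compounds alone.

Of the compounds shown here, two sharing one core have so far been measured in a functional assay for agonist activity at G protein-coupled receptor 88 (Homo sapiens), read by HTRF and cAMP accumulation; on this read-out higher numbers stand for an effect only at larger amounts of compound and lower numbers for an effect already at smaller amounts. Compound 1 `CC[C@H](C)[C@H](N)CN(C(=O)[C@@H]1C[C@H]1c1cccc(Cl)c1)c1ccc(-c2ccccc2)cc1` gives 2200 nM. Compound 2 `CC[C@H](C)[C@H](N)CN(C(=O)[C@@H]1C[C@H]1c1ccc(F)cc1)c1ccc(-c2ccccc2)cc1` gives 600 nM. Among the compounds with values here, compound 2 thus stands with the lower of the two numbers, and the step of a 3.7-fold lower number from compound 1 to compound 2 (0.56 log units; beyond the scatter) is the only measured comparison available; it changes both the halogen and where it sits in a single move. Compound 3 `CC[C@H](C)[C@H](N)CN(C(=O)[C@@H]1C[C@H]1c1cccc(F)c1)c1ccc(-c2ccccc2)cc1` has not yet been measured. It differs from compound 2 by 3-fluorophenyl in place of 4-fluorophenyl on a saturated ring carbon, so the halogen stays a fluorine and only its position changes. Within the data shown here, no measured step separates the effect of the halogen from the effect of its position, so the one step at hand bears on this change only in part. Because compound 1 with its 3-chlorophenyl gives 2200 nM while compound 2 with its 4-fluorophenyl gives 600 nM, a number for compound 3 between them, or close to that of compound 2, seems most plausible. The expected step is a 1.8-fold higher number from compound 2 to compound 3 (0.26 log units; within the scatter), a modest rise. Compound 3 is therefore estimated at 1100 nM, within a range from 400 nM to 3000 nM.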

Compound 3, half-maximal effective concentration: 560 nM
Estimate against measurement, compound 3: 2.0-fold (0.29 log units) above; low and high end bracket the measured number.
By their numbers in this assay, from the lowest: compounds 3 and 2 (each within the scatter of the next); then compound 1.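

In this assay, moving the fluorine, with 3-fluorophenyl in place of 4-fluorophenyl on a saturated ring carbon, gives a 1.1-fold lower number from compound 2 to compound 3 (0.03 log units; within the scatter) and so, for fluorine, this shift in position makes no difference that can be told from the usual scatter. Compound 3 also supplies the clean comparison that was missing, as it keeps the position of compound 1 and changes only the halogen: fluoro in place of chloro gives a 3.9-fold lower number from compound 1 to compound 3 (0.59 log units; beyond the scatter) and this step is beyond the scatter, so the gap first seen between compound 1 and compound 2 now reads as belonging to the halogen rather than to its position. Nothing shown here explains why swapping the halogen registers in this read-out while moving the fluorine does not.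

Within the data shown here, compound 1 is the only chloro compound among the three, so whether position is equally unimportant for chlorine remains unknown, as does the outcome with 4-chlorophenyl. Going by these compounds, it is also open whether the flat result for position holds beyond fluorine for other groups on this phenyl ring, such as methoxy, a nitrile or trifluoromethyl, or for a plain phenyl with no substituent.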